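A small end group swapped for a ring

The source may report more compounds than this note shows. Statements on the series, on what has been measured and on what is new or still open speak of the compounds shown alone.

In a functional assay on HCT-116 cells (Homo sapiens) for inhibition, read by colorimetric assay, with a stated time of 3 days (a lower number here means a stronger inhibitor, a higher number a weaker inhibitor), compound 1 `NC(=O)C(=O)NCCCCCC(=O)Nc1ccccc1` gives > 100000 nM, which is a limit and not a number. Compound 2 `CC(=O)C(=O)NCCCCCCC(=O)Nc1ccccc1` gives > 100000 nM, also a limit. Compound 3 `O=C(CCCCCCC(O)C(F)(F)F)Nc1ccccc1` gives > 40000 nM, again a limit. Compound 1 therefore stands with the other two at the limits of the assay, as the limit of > 100000 nM in this assay, at which 2 of the 3 values shown sit, and the limit of > 40000 nM in this assay, at which 1 of the 3 values shown sits, show, and no true number exists yet.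

Compound 4 `O=C(CCCCCNC(=O)c1cc(=O)c(O)co1)Nc1ccccc1` keeps the core of compound 1 but changes its end, on a carbonyl carbon: a group of 8 heavy atoms (5 carbon, 3 oxygen; one six-membered aromatic ring with 1 hetero atom) in place of a group of 3 heavy atoms (1 carbon, 1 nitrogen, 1 oxygen; no ring), on a carbonyl carbon. The new group is much larger and carries a six-membered aromatic ring.

The closest guides are other changes at this end of the chain: a step that the two limits leave unreadable from compound 1 to compound 2, a step that the two limits leave unreadable from compound 1 to compound 3 and a step that the two limits leave unreadable from compound 2 to compound 3. Going by the values given here, none of these has a readable size, so they predict no step of known size or direction. The best expectation is that this assay stays weak. The expected change is an at least 1.4-fold lower number from compound 1 to compound 4 (0.15 log units; that floor lies within the scatter). Compound 4 is estimated at 70000 nM, with an expected range from 20000 nM to 200000 nM.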

Compound 4, half-maximal inhibitory concentration: > 100000 nM
Compound 4: no number, only a limit; the forecaster's own chance of this, stated with the estimate: 65%; at least 1.4-fold (0.15 log units) between middle value and limit.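

Compound 1 and compound 4 both give only a limit in this assay, so no step can be read between them: the limit of > 100000 nM in this assay, at which 3 of the 4 values shown sit.

The compounds shown leave open whether any change at this end of the chain can give a true number in this assay.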